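The compounds below may be only part of what the source reports. "The series", "measured", "known", "first", "only" and "open" are said of these compounds alone.

Measured so far:
Compound 1 `COc1ccc(C(=O)/C=C/c2cccc(F)c2)c2c1C=CC(C)(C)O2`: in a functional assay on SK-OV-3 cells (Homo sapiens) for antiproliferative activity, read by MTT assay, with a stated time of 24 h (on this read-out lower numbers stand for stronger inhibition and higher numbers for weaker inhibition), compound 1 gives > 10000 nM, which is a limit of the assay.
Compound 2 `COc1ccc(C(=O)/C=C/c2cccc3ccccc23)c2c1C=CC(C)(C)O2`: in this assay compound 2 gives > 10000 nM, also a limit.

Compound 1 thus stands at the limit rather than at a number; both values shown sit there, as seen in the limit of > 10000 nM in this assay, at which 2 of the 2 values shown sit. Compound 3 `COc1ccc(C(=O)/C=C/c2ccc(Cl)c(Cl)c2)c2c1C=CC(C)(C)O2` carries 3,4-dichlorophenyl in place of 3-fluorophenyl on a double-bonded chain carbon bound to a double-bonded chain carbon. Among the compounds with values here, no measured step covers this change. In this assay the step is expected to be small or none beyond the scatter, with no set direction. Compound 3 is estimated at 10000 nM, range 3000 nM to 30000 nM. The expected step is a number no higher from compound 1 to compound 3 (the limit leaves the size open).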

Compound 3, half-maximal inhibitory concentration: 9940 nM
For compound 3 the middle estimate is 1.0-fold (0.00 log units) above the measured one, within the range that was stated.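

In this assay compound 3 gives 9940 nM, so a group on a double-bonded chain carbon bound to a double-bonded chain carbon can yield a readable number here. Changing to 3,4-dichlorophenyl from 3-fluorophenyl gives a number no higher from compound 1 to compound 3 (the limit leaves the size open), and the size of this step cannot be read. The limit still governs most of the series: the limit of > 10000 nM in this assay, at which 2 of the 3 values shown sit.

As far as these compounds go, whether an amine or a carboxylic acid on this phenyl ring would give a value clearly lower than that of compound 3 remains open. From the compounds shown here alone, the effect of any change to the shared core also remains open.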